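The source may hold more compounds than are shown below. What is called first, only, known or untested is meant among the compounds shown, and "the series" means these compounds.

Measured so far:
- compound 1, `Cc1cc(SC(C)C)c(S(C)(=O)=O)cc1C(=O)N=C(N)N`: 12 nM
- compound 2, `Cc1cc(N2CCC(N)CC2)c(S(C)(=O)=O)cc1C(=O)N=C(N)N`: 9.8 nM

Both numbers come from a functional assay for inhibition of sodium/hydrogen exchanger (Oryctolagus cuniculus); a higher number here means a weaker inhibitor, a lower number a stronger inhibitor. Compound 2 gives 9.8 nM there, the lowest of the two numbers, with compound 1 nearest at 12 nM; the two lie within the scatter of each other, so no order can be read from them.

The step from compound 1 to compound 2 exchanges isopropylsulfanyl for 4-aminopiperidin-1-yl on the aromatic carbon and gives a 1.2-fold lower number from compound 1 to compound 2 (0.09 log units; within the scatter): the position accepts two quite different groups without a change beyond the scatter.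

Compound 3, `Cc1cc(Nc2cccc(Cl)c2)c(S(C)(=O)=O)cc1C(=O)N=C(N)N`, is not yet measured. It differs from compound 2 by (3-chlorophenyl)amino in place of 4-aminopiperidin-1-yl on an aromatic carbon.

Going by the values given here, only the step from compound 1 to compound 2 bears on this change, and it was flat. Among the compounds with values here, no measured compound carries an arylamino group at this position, so the new group itself is untested. The expectation rests on that single flat step, a 1.2-fold lower number from compound 1 to compound 2 (0.09 log units; within the scatter). The expected step is a 1.5-fold higher number from compound 2 to compound 3 (0.18 log units; within the scatter) in this assay, essentially none beyond the scatter, with a wide range to cover the untested group.

Compound 3 is estimated at 15 nM, expected between 4 nM and 60 nM.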

Compound 3, half-maximal inhibitory concentration: 33 nM
The estimate for compound 3 lay 2.2-fold (0.34 log units) below the measured number; the measured number falls inside the stated range.
By their numbers in this assay, from the lowest: compounds 2 and 1 (each within the scatter of the next); then compound 3.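

In this assay, this position is not indifferent to every group placed on it: (3-chlorophenyl)amino gives a 3.4-fold higher number from compound 2 to compound 3 (0.53 log units; beyond the scatter) and a 2.8-fold higher number from compound 1 to compound 3 (0.44 log units; beyond the scatter), whereas isopropylsulfanyl and 4-aminopiperidin-1-yl could not be separated. The loss is modest, and compound 3 still reads 33 nM, so an aromatic ring of carbon only is accepted on an amino link at this carbon, ortho to the methylsulfonyl group, though at some cost against both earlier groups. The change replaces a non-aromatic ring with an aromatic one and brings in chlorine at the same time, and no available data bear on the reason for the shift.

The compounds shown leave open which part of the (3-chlorophenyl)amino group carries the loss; phenylamino without the chlorine, or a fluorine in place of the chlorine, would begin to separate the ring from the halogen. Also open, as far as these compounds go, is how a non-aromatic ring on the same amino link, such as cyclohexylamino, or another saturated amine, such as piperazin-1-yl, would read against compound 2 in this assay.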